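Swapping a methoxy for a bromo on a shared core

The compounds below may be only part of what the source reports. "The series", "measured", "known", "first", "only" and "open" are said of these compounds alone.

Measured so far, in a toxicity assay on the whole organism with Rattus norvegicus as the target, at a dose of 400 mg/kg by the oral route; on this read-out higher numbers stand for a stronger effect at the one dose given and lower numbers for a weaker effect:
Compound 1, `COc1ccc(OCC2=NCCO2)cc1`: 90%
Compound 2, `Clc1ccccc1OCC1=NCCO1`: 60%
Compound 3, `Cc1cc(OCC2=NCCO2)ccc1Cl`: 100%

All three compounds share the same core and differ only in what sits on the aromatic ring. Among these three numbers, compound 1 stands second highest. Its nearest neighbour is compound 3, whose value lies close to it, a gap that falls within the usual scatter of this assay, so the two cannot be told apart. Its furthest neighbour is compound 2, whose value lies well below it, a gap beyond the scatter, so compound 1 is the more active of that pair.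

The next compound, compound 4, `Brc1ccc(OCC2=NCCO2)cc1`, has not yet been measured. It differs from compound 1 in one place: bromo in place of methoxy on an aromatic carbon. Among the compounds with values here, no step between measured compounds matches this change, so there is no direct precedent to lean on.

Since the two substituents on the aromatic ring seen so far that keep the read-out high sit on compounds 1 and 3, a bromo on the same core is expected to behave similarly. The step from compound 1 to compound 4 in this assay is estimated at a number 5 percentage points lower from compound 1 to compound 4 (within the scatter), a small downward move that stays within the scatter. For compound 4 the expected value is 85%, with a range from 60% to 100%.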

Compound 4, a percentage reported as activity, at one dose (the size of the read-out at that dose, not a potency): 100%
Compound 4: middle estimate off by 15 percentage points, on the low side; measured number inside the range.
By their numbers in this assay, from the lowest: compound 2; then compounds 1, 3 and 4 (each within the scatter of the next).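

In this assay, bromo in place of methoxy on an aromatic carbon, para to a group of 7 heavy atoms, gives a number 10 percentage points higher from compound 1 to compound 4 (within the scatter) so at this position the two groups cannot be told apart. Within the data shown here, this is the first pair in the set that differs in one place only, and it gives the first direct reading of a single change on the ring: a methoxy with 2 heavy atoms and 1 hydrogen-bond acceptor gives way to a bromo with 1 heavy atom and 0 hydrogen-bond acceptors, with no difference this read-out can resolve. Nothing available here speaks to why the two groups read alike.

From the compounds shown here alone, whether an amine or a carboxylic acid at this same position, or a longer chain such as a butoxy group in place of the methoxy, would keep the read-out in the same range stays open. Going by these compounds, a single dose shows only the size of the effect at that dose, so any difference between compound 1 and compound 4 at other doses also remains unknown.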